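This account rests on a few compounds, and the source may have more. Where it says the series, first, only, none or still open, it means among the compounds named here.

Measured so far in an in vitro functional assay on HEK285-7 cells for antagonist activity at prostaglandin D2 receptor 2 (Homo sapiens), read by BRET and beta-arrestin recruitment; a lower number here means a stronger inhibitor, a higher number a weaker inhibitor:
compound 1, `O=C(O)Cc1sc(NCc2ccccc2)nc1-c1ccc(Cl)cc1`: 2300 nM
compound 2, `O=C(O)Cc1sc(C(c2ccccc2)c2ccccc2)nc1-c1ccccc1`: 370 nM
compound 3, `O=C(O)Cc1sc(C(c2ccc(F)cc2)c2ccc(F)cc2)nc1-c1cc(F)cc(F)c1`: 340 nM

Among these three, compound 3 has the lowest number. Its nearest neighbour is compound 2, whose value lies within the usual scatter of repeated measurements, so the two cannot be told apart. Compound 1 stands furthest away, with a number clearly beyond the scatter, so compound 1 is the weaker inhibitor of the set.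

Compound 4, `Cc1cc(-c2nc(C(c3ccc(F)cc3)c3ccc(F)cc3)sc2CC(=O)O)ccn1`, has not yet been measured. It differs from compound 3 in one place: 2-methylpyridin-4-yl in place of 3,5-difluorophenyl on an aromatic carbon. The shared core, the carboxymethyl group and the large group on the other ring carbon are kept unchanged.

Among the compounds with values here, no measured pair shows this kind of exchange, so the effect can only be guessed from the tolerance seen between compound 2 and compound 3. The step of a 1.1-fold lower number from compound 3 to compound 4 (0.05 log units; within the scatter) is expected to be small, with no clear direction beyond the scatter. In this assay compound 4 is therefore estimated at 300 nM, within a range from 100 nM to 900 nM.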

Compound 4, half-maximal inhibitory concentration: 53 nM
Compound 4: the middle estimate sits 5.7-fold (0.75 log units) above what was measured; measured number outside the range, below it.
By their numbers in this assay, from the lowest: compound 4; then compounds 3 and 2 (each within the scatter of the next); then compound 1.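

In this assay, within the data shown here, the group on the aromatic carbon next to the ring nitrogen proves able to shift the number clearly, which the earlier compounds could not show. Putting 2-methylpyridin-4-yl in place of 3,5-difluorophenyl gives a 6.4-fold lower number from compound 3 to compound 4 (0.81 log units; beyond the scatter), so compound 4 is the stronger inhibitor of this pair. The exchange changes several things at once, removing both fluorine atoms and bringing in a ring nitrogen and a methyl group, and nothing shown gives a reason for the gain.

On these data alone, whether the ring nitrogen or the methyl group matters more stays open; a pyridin-4-yl group without the methyl, or a methylphenyl group, would separate the two. Also open, as far as these compounds go, is whether the gain would persist with a different large group on the other ring carbon.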